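The source may hold more compounds than are shown below. What is called first, only, known or untested is meant among the compounds shown, and "the series" means these compounds.

Compound 1 `O=C1N=C(N2N=C(c3ccccc3)CC2c2ccccc2O)S/C1=C1/C(=O)Nc2ccccc21` gives 17800 nM in a functional assay on cells (Cancer cell lines, Homo sapiens) for cytotoxicity, read by sulforhodamine B assay, with a stated time of 48 h; on this read-out lower numbers stand for stronger inhibition of growth and higher numbers for weaker inhibition of growth. Compound 2 `O=C1N=C(N2N=C(c3ccccc3)CC2c2ccccc2O)S/C1=C1/C(=O)Nc2ccc(Br)cc21` differs from it by a single change, (bromo in place of hydrogen on an aromatic carbon), and in this assay compound 2 gives 630 nM, a step of a 28-fold lower number from compound 1 to compound 2 (1.45 log units; beyond the scatter). Compound 3 `COc1ccc(C2=NN(C3=NC(=O)/C(=C4\C(=O)Nc5ccccc54)S3)C(c3ccc(OC)cc3)C2)cc1` carries a different core; the difference between the two cores is not broken down here. In this assay compound 3 gives 100000 nM, the highest number of the three measured compounds, and its steps to compound 1 and to compound 2 both lie beyond the scatter.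

Compound 4 `COc1ccc(C2=NN(C3=NC(=O)/C(=C4\C(=O)Nc5ccc(Br)cc54)S3)C(c3ccc(OC)cc3)C2)cc1` is the unmeasured partner of compound 3. It arises from compound 3 by bromo in place of hydrogen on an aromatic carbon, the same change, at the same kind of place, that separates compound 1 from compound 2. Among the compounds with values here, since that change gave a 28-fold lower number from compound 1 to compound 2 (1.45 log units; beyond the scatter), a step of similar direction but more modest size is expected from compound 3 to compound 4, namely an 8.3-fold lower number from compound 3 to compound 4 (0.92 log units; beyond the scatter), the caution resting on the single precedent and on the high starting number of compound 3 at 100000 nM. Compound 4 is therefore expected to give about 12000 nM, estimated to fall between 3000 nM and 60000 nM.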

Compound 4, concentration for total growth inhibition: 380 nM
The estimate for compound 4 lay 32-fold (1.50 log units) above the measured number; the whole stated range lies above it.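

In this assay bromo in place of hydrogen on an aromatic carbon gave a 260-fold lower number from compound 3 to compound 4 (2.42 log units; beyond the scatter) and so lowered the number on both cores shown, by a large step each time. The direction of the change carried over from the core of compound 1 to the core of compound 3, but its size did not carry over, as the two steps stand apart by more than the scatter: the same change on two cores in this assay, a 28-fold lower number (1.45 log units; beyond the scatter) from compound 1 to compound 2 and a 260-fold lower number (2.42 log units; beyond the scatter) from compound 3 to compound 4, 9.3-fold (0.97 log units) apart, beyond the scatter of two such steps. Within the data shown here, with only two pairs, this shows that the size of the step can depend on the core, but it does not show which feature of the cores sets that size, and it gives no rule for a further core.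

The compounds shown leave open whether chloro, fluoro or an amine in the same place would give a step like that of bromo. They also leave open whether bromo on another aromatic carbon of that ring would do the same on either core.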